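From pyridin-3-yl to pyridin-4-yl in compound 3

The source may hold more compounds than are shown below. What is called first, only, known or untested is meant among the compounds shown, and "the series" means these compounds.

Measured so far in a physicochemical assay for lipophilicity, read by HPLC; a lower number here means a more polar compound, a higher number a more lipophilic compound
- compound 1 `CC(=O)NC[C@H]1CN(c2ccc(OC[C@@H](O)CNc3ccccc3)c(F)c2)C(=O)O1` gives 1.42 as its value
- compound 2 `CC(=O)NC[C@H]1CN(c2ccc(OC[C@H](O)CNc3ccccc3)c(F)c2)C(=O)O1` gives 0.59 as its value
- compound 3 `CC(=O)NC[C@H]1CN(c2ccc(OC[C@@H](O)CNc3cccnc3)c(F)c2)C(=O)O1` gives 0.02 as its value

Compound 3 stands lowest of the three in this assay, with compound 2 nearest to it and compound 1 furthest. Compound 4 `CC(=O)NC[C@H]1CN(c2ccc(OC[C@@H](O)CNc3ccncc3)c(F)c2)C(=O)O1` differs from it by one change, (pyridin-4-yl in place of pyridin-3-yl on an amine nitrogen), which places pyridin-4-yl where pyridin-3-yl stood on an amine nitrogen.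

Going by the values given here, no measured step makes this exchange. The closest is a number 1.40 log units lower from compound 1 to compound 3 (beyond the scatter), a large step that brings in pyridin-3-yl in place of phenyl. The step of a number 0.57 log units lower from compound 2 to compound 3 (beyond the scatter) is modest but also includes a change in configuration as drawn, so it says less. The modest step of a number 0.83 log units lower from compound 1 to compound 2 (beyond the scatter) comes with the fact that compounds 1 and 2 differ only in the configuration as drawn and shows that this read-out can move beyond the scatter while the atoms stay the same, so the range must stay wide.

The two groups count alike, so only a slight fall, within the scatter, is expected. The estimated change is a number 0.17 log units lower from compound 3 to compound 4 (within the scatter) and rests on this comparison alone. Compound 4 is expected at -0.15 in this assay, with an estimated range from -0.8 to 0.35 as its likely span.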

Compound 4, partition coefficient: -0.04
Beside the measured number, compound 4's estimate is 0.11 log units below it; the range from low to high includes it.
By their numbers in this assay, from the lowest: compounds 4 and 3 (each within the scatter of the next); then compound 2; then compound 1.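

In this assay the exchange of pyridin-3-yl for pyridin-4-yl on the amine nitrogen comes to a number 0.06 log units lower from compound 3 to compound 4 (within the scatter), so the two pyridine groups cannot be told apart at this position. Going from phenyl to pyridin-4-yl is also a large step, a number 1.46 log units lower from compound 1 to compound 4 (beyond the scatter), which shows that the large fall from phenyl is not tied to pyridin-3-yl alone. The step of a number 0.63 log units lower from compound 2 to compound 4 (beyond the scatter) also carries a change in configuration as drawn, so it says less about the ring, and configuration alone already moves this read-out: the fact that compounds 1 and 2 differ only in the configuration as drawn

The compounds shown leave open whether pyridin-2-yl or a pyrimidine ring on the same amine nitrogen would fall with these two pyridine groups or nearer phenyl in this assay. They also leave open how pyridin-4-yl reads with the other configuration at the saturated chain carbon.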